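The compounds below may be only part of what the source reports. "The series", "measured", "known", "first", "only" and "open" are said of these compounds alone.

Measured compounds:
Compound 1 `O=[N+]([O-])c1cccc(CNc2cc(C(F)(F)F)cc3[nH]ncc23)c1` gives 69% in an assay for inhibition of Indoleamine 2,3-dioxygenase 1 (Homo sapiens), with stated times of 10 min and 60 min, tested at 100 uM; a higher number here means a stronger effect of the compound at the concentration tested, a lower number a weaker effect.
Compound 2 `O=[N+]([O-])c1ccc(O)cc1CNc1cc(Br)cc2[nH]ncc12` gives 98% in this assay.
Compound 3 `O=[N+]([O-])c1cccc(CNc2cc(Br)cc3[nH]ncc23)c1` gives 95% in this assay.

Compound 1 stands lowest of the three numbers; its nearest neighbour is compound 3, a number 26 percentage points higher from compound 1 to compound 3 (beyond the scatter), a step reached by bromo in place of trifluoromethyl on the shared core. Compound 2 and compound 3 show values within the scatter of each other. Compound 4 `FC(F)(F)c1cc(NCc2cccc(Br)c2)c2cn[nH]c2c1` differs from compound 1 in another way: bromo in place of nitro on an aromatic carbon. Among the compounds with values here, no measured step touches that place, so the only guide is the value of compound 1 itself. The account therefore expects a number 1 percentage points lower from compound 1 to compound 4 (within the scatter) in this assay, with no step beyond the scatter. Compound 4 is estimated at 68%, between 45% and 88%.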

Compound 4, a percentage reported as inhibition, at one concentration (the size of the read-out at that concentration, not a potency): 51%
Estimate against measurement, compound 4: 17 percentage points above, within the range that was stated.
By their numbers in this assay, from the lowest: compound 4; then compound 1; then compounds 3 and 2 (each within the scatter of the next).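

In this assay, within the data shown here, bromo in place of nitro gives a number 18 percentage points lower from compound 1 to compound 4 (beyond the scatter), the first measured step at this place, meta to a large group. The read-out therefore depends on the group held here, at least with trifluoromethyl elsewhere on the shared core, and nitro is not freely exchanged for bromo. Nothing available explains this step.

The compounds shown leave open whether the same change would carry the same size with bromo in place of trifluoromethyl on the core. They also leave open how an amine or a carboxylic acid would read at this place.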